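The compounds below may be only part of what the source reports. "The series", "measured", "known", "first", "only" and "open" are said of these compounds alone.

In an ADME assay on Akata cells (Homo sapiens) for cytotoxicity (a higher number here means that more compound is tolerated, a lower number that less compound is tolerated), compound 1 `Nc1ncnc2c1ncn2/C=C1\C[C@@H]1[C@H](O)CO` gives 57000 nM, compound 2 `Nc1nc2c(ncn2/C=C2/CC2(CO)CO)c(=O)[nH]1` gives 46000 nM and compound 3 `Nc1nc2c(ncn2/C=C2\C[C@H]2[C@@H](O)CO)c(=O)[nH]1` gives 75000 nM. Compound 1 thus stands within the scatter of both other compounds, so these values show no separation. Compound 4 `Nc1ncnc2c1ncn2/C=C1/C[C@@H]1[C@@H](O)CO` has the same atoms and bonds as compound 1 and differs only in configuration as drawn: the two compounds have the same atoms and bonds and differ only in configuration as drawn: 2 of 3 stereo elements differ; a stereocentre at a saturated chain carbon is drawn S in compound 1 and R in compound 4; a double bond is drawn E in compound 1 and Z in compound 4. A stereocentre at a saturated chain carbon is drawn S in compound 1 and R in compound 4, and a double bond is drawn E in compound 1 and Z in compound 4. Among the measured compounds shown here, no measured pair isolates either change, so no shift beyond the scatter is expected, in either direction. The estimated 1.1-fold lower number from compound 1 to compound 4 (0.04 log units; within the scatter) stays within the scatter. For compound 4, the expected value is 52000 nM, with an estimated range of 22000 nM to 110000 nM.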

Compound 4, half-maximal cytotoxic concentration: 55000 nM
The estimate for compound 4 lay 1.1-fold (0.02 log units) below the measured number, within the range that was stated.
By their numbers in this assay, from the lowest: compounds 2, 4, 1 and 3 (each within the scatter of the next).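

a 1.0-fold lower number from compound 1 to compound 4 (0.02 log units; within the scatter) in this assay is the first step read between two measured compounds. Changing the stereocentre at the saturated chain carbon and the double bond together gives no shift beyond the scatter, so this pair shows no sensitivity to these two configuration changes taken together, and the comparison is clean on constitution: the fact that compounds 1 and 4 differ only in the configuration as drawn.

From the compounds shown here alone, the two stereo elements changed together, so the contribution of each alone stays open. Going by these compounds, whether an amine or a carboxylic acid on the chain would move the number beyond the scatter also stays open.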